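Trimming the sulfonamide amine: piperidine to dimethylamino

A few compounds are considered here, and "the series" means these few. Any claim that something is new, unique, unknown or untested is made for them only; others in the source may bear on it.

Measured compounds:
- compound 1 `CCN(CC)S(=O)(=O)c1ccc(S(=O)(=O)N2CCC[C@@H](C(=O)N3CCN(C(=O)OC(C)(C)C)CC3)C2)cc1`: 10 nM
- compound 2 `CCOC(=O)[C@@H]1CCCN(S(=O)(=O)c2ccc(S(=O)(=O)N3CCCCC3)cc2)C1`: 1000 nM
- compound 3 `CCN(CC)S(=O)(=O)c1ccc(S(=O)(=O)N2CCC[C@@H](c3nc(C)no3)C2)cc1`: 700 nM

In a functional assay on MIA PaCa-2 cells (Homo sapiens) for inhibition, read by MTT assay, with a stated time of 3 days (a higher number here means a weaker inhibitor, a lower number a stronger inhibitor), compound 2 gives 1000 nM, the highest number among the three measured compounds. The nearest value is that of compound 3, which in this assay gives 700 nM; the two lie within the usual scatter of each other, so no order between them can be read. Compound 1, which in this assay gives 10 nM, stands well beyond the scatter from compound 2, but it differs from compound 2 in several places at once, so no single change can be credited for that gap.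

Compound 4 `CCOC(=O)[C@@H]1CCCN(S(=O)(=O)c2ccc(S(=O)(=O)N(C)C)cc2)C1` is not yet measured. It differs from compound 2 in one place only:

dimethylamino in place of piperidin-1-yl on a sulfonyl sulfur

For the measured compounds named here, no pair of measured compounds isolates this change, so there is no measured step to lean on. Going by the values given here, both groups are amines of similar kind on the same sulfonyl sulfur, and nothing among the measured compounds points to a large effect of such a change. The step from compound 2 to compound 4 is therefore expected to be small, no change at the digits printed from compound 2 to compound 4 (within the scatter), in no direction beyond the scatter. For compound 4 the estimate in this assay is 1000 nM, with a range from 300 nM to 3000 nM.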

Compound 4, half-maximal inhibitory concentration: 300 nM
Estimate against measurement, compound 4: 3.3-fold (0.52 log units) above, and the stated range covers the measured number.
By their numbers in this assay, from the lowest: compound 1; then compound 4; then compounds 3 and 2 (each within the scatter of the next).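

In this assay, replacing piperidin-1-yl with dimethylamino on a sulfonyl sulfur gives a 3.3-fold lower number from compound 2 to compound 4 (0.52 log units; beyond the scatter) and so makes compound 4 a modestly stronger inhibitor. For the compounds shown here, this is the first single change that can be read on its own in this set, and it shows that the amine on this sulfur can shift the number beyond the usual scatter, even though the other parts of the molecule stay the same. It also shows that, with the ethyl ester in place, the six-membered ring of 6 heavy atoms is not needed for activity, as the open group of 3 heavy atoms does better, but nothing available explains why this change lowers the number.

Pyrrolidin-1-yl or a plain amino group on the same sulfur could help separate the loss of the ring from the lower count of heavy atoms. From the compounds shown here alone, compound 1 and compound 3 carry diethylamino on this sulfur but also differ from compound 4 elsewhere, so whether the step holds away from the ethyl ester stays open.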